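Adding a Methoxy Group to Compound 2

The source may hold more compounds than are shown below. What is called first, only, known or untested is meant among the compounds shown, and "the series" means these compounds.

compound 1 `CC(C)C[C@@H]1C[C@H](Cl)C[C@H](CC(C)C)O1`: 67000 nM
compound 2 `CC(C)C[C@H]1C[C@@H](Cl)C[C@@H](c2ccccc2)O1`: 24000 nM

In a functional assay on SW1573 cells (Homo sapiens) for antiproliferative activity (on this read-out lower numbers stand for stronger inhibition of growth and higher numbers for weaker inhibition of growth), compound 2 gives 24000 nM, the lower of the two numbers measured, whereas compound 1 gives 67000 nM, a gap that lies beyond the usual scatter. Compound 3 `COc1ccc([C@@H]2C[C@H](Cl)C[C@H](CC(C)C)O2)cc1` differs from compound 2 by methoxy in place of hydrogen on an aromatic carbon. For the measured compounds named here, no measured pair shows what this change does here, so no step beyond the scatter is expected in this assay in either direction. Compound 3 is therefore estimated at 20000 nM, with a range from 7000 nM to 60000 nM, which corresponds to an expected step of a 1.2-fold lower number from compound 2 to compound 3 (0.08 log units; within the scatter).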

Compound 3, concentration for 50% growth inhibition: 30000 nM
For compound 3 the middle estimate is 1.5-fold (0.18 log units) below the measured one, within the range that was stated.
By their numbers in this assay, from the lowest: compounds 2 and 3 (each within the scatter of the next); then compound 1.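

In this assay, methoxy in place of hydrogen on an aromatic carbon, para to a large group, gives a 1.3-fold higher number from compound 2 to compound 3 (0.10 log units; within the scatter) and so leaves the two compounds indistinguishable. For the compounds shown here, this is the first sign that this place on the aromatic ring accepts a methoxy group without a step beyond the scatter. Nothing available explains this outcome.

The compounds shown leave open whether an amine or a carboxylic acid at this place would behave in the same way. They also do not show whether a longer chain, such as butoxy, would stay within the scatter of compound 2.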